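Fluoro to methyl on the sulfonyl aryl of compound 1

A few compounds are considered here, and "the series" means these few. Any claim that something is new, unique, unknown or untested is made for them only; others in the source may bear on it.

Measured in a functional assay on A549 cells (Homo sapiens) for antiproliferative activity, read by MTT assay, with a stated time of 72 h; on this read-out higher numbers stand for weaker inhibition and lower numbers for stronger inhibition:
- compound 1 `CCN(CC)CCNC(=O)Nc1nc2ccc(-c3cnc(OC)c(NS(=O)(=O)c4ccc(F)cc4)c3)cc2s1` gives 450 nM
- compound 2 `COc1ncc(-c2ccc3nc(NC4CC4)sc3c2)cc1NS(=O)(=O)c1ccc(F)cc1` gives 1330 nM

Within the data shown here, compound 1 holds the lowest of the two numbers measured so far; its nearest neighbour is compound 2, reached by the step of a 3.0-fold higher number from compound 1 to compound 2 (0.47 log units; beyond the scatter), which is cyclopropyl in place of (2-(diethylamino)ethyl)carbamoyl on a nitrogen on an aromatic ring.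

Compound 3 `CCN(CC)CCNC(=O)Nc1nc2ccc(-c3cnc(OC)c(NS(=O)(=O)c4ccc(C)cc4)c3)cc2s1` keeps the shared core and the (2-(diethylamino)ethyl)carbamoyl group of compound 1 and differs only by methyl in place of fluoro on an aromatic carbon. The change sits on an aromatic carbon of a six-membered aromatic ring of carbon only, para to a large group, that is, (4-fluorophenyl)sulfonyl becomes (4-methylphenyl)sulfonyl.

Among the measured compounds shown here, none of the measured steps bears on this change: the only step measured, from compound 1 to compound 2, alters a different place and leaves the sulfonyl aryl untouched. There is therefore no measured basis for expecting a shift in either direction, and the expected step of no change at the digits printed from compound 1 to compound 3 (within the scatter) is taken as none beyond the scatter. Compound 3 is estimated at 450 nM, with a range of 200 nM to 1000 nM.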

Compound 3, half-maximal inhibitory concentration: 310 nM
The estimate for compound 3 lay 1.5-fold (0.16 log units) above the measured number; measured number inside the range.
By their numbers in this assay, from the lowest: compounds 3 and 1 (each within the scatter of the next); then compound 2.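

In this assay, among these compounds, the exchange at the sulfonyl aryl, methyl in place of fluoro on an aromatic carbon para to a large group, gives a 1.5-fold lower number from compound 1 to compound 3 (0.16 log units; within the scatter) and is the first reading of this position. With the (2-(diethylamino)ethyl)carbamoyl group and the shared core held constant, this read-out does not separate (4-fluorophenyl)sulfonyl from (4-methylphenyl)sulfonyl, so the number is kept when one of these single-atom substituents replaces the other, whereas the earlier step between compound 1 and compound 2 spoke only to the group on the nitrogen. No measurement at hand offers a reason for this outcome.

Still open, as far as these compounds go, is how this aromatic carbon responds to groups unlike fluoro and methyl, such as an amine, a carboxylic acid or a longer chain like n-butyl, all of which would test the position more widely than this single pair can. Also open, from the compounds shown here alone, is whether the same exchange stays equally quiet when cyclopropyl, as in compound 2, sits on the nitrogen in place of the (2-(diethylamino)ethyl)carbamoyl group.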